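Shortening the chain on the triazole of compound 3

The compounds below may be only part of what the source reports. "The series", "measured", "known", "first", "only" and "open" are said of these compounds alone.

Three compounds have been run through an ADME assay on microsomes from liver (Mus musculus, strain NMRI) for metabolic stability, tested at 2.5 uM; on this read-out lower numbers stand for slow clearance and higher numbers for fast clearance. Compound 1, `Clc1ccc(-c2ccc(Cn3nnc4ccccc43)cn2)cc1`, gives 3.8 mL/min/g, and compound 2, `Fc1cc(Cl)ccc1-c1ccc(Cn2nnc3c(Br)cccc32)cn1`, gives 3.8 mL/min/g. Compound 3, `Brc1cccc2c1nnn2CC1CCCC1`, gives 11.4 mL/min/g, the highest of the three numbers and separated from both of the others by gaps that lie beyond the usual scatter of repeated measurements, so compound 3 is the one cleared fastest among them. Compound 1 and compound 2 stand within the scatter of each other.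

Compound 4, `CCCn1nnc2c(Br)cccc21`, has not yet been measured. It differs from compound 3 in one place: ethyl in place of cyclopentyl on a saturated chain carbon bound to an aromatic nitrogen. Among the compounds with values here, no pair of measured compounds shows this change, so its effect on this assay must be estimated from the general picture rather than read from a measured step. Compound 3 carries the highest number among the three, and the two compounds that differ more broadly from it in the group on the chain carbon bound to the aromatic nitrogen both come out lower, so a modest move downward is expected for compound 4, of a size that may still fall within the scatter, a 1.9-fold lower number from compound 3 to compound 4 (0.28 log units; within the scatter). Compound 4 is therefore expected to give about 6 mL/min/g, between 3 mL/min/g and 12 mL/min/g.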

Compound 4, intrinsic clearance in a liver preparation (reported as CLH), per the amount of preparation that the assay uses: 7.7 mL/min/g
For compound 4 the middle estimate is 1.3-fold (0.11 log units) below the measured one, and the stated range covers the measured number.
By their numbers in this assay, from the lowest: compounds 1 and 2 (each within the scatter of the next); then compounds 4 and 3 (each within the scatter of the next).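

Within the data shown here, replacing cyclopentyl with ethyl on a saturated chain carbon bound to an aromatic nitrogen gives the first step in which only this group changes, and in this assay it reads a 1.5-fold lower number from compound 3 to compound 4 (0.17 log units; within the scatter) and so stays within the scatter of repeated measurements. Going from 5 heavy atoms with one five-membered non-aromatic ring of carbon only to 2 heavy atoms with no ring leaves compound 3 and compound 4 indistinguishable on this read-out, so at this position the change brings no clear shift in clearance in either direction. Nothing at hand bears on why these two compounds read alike. 

Among these compounds, this single step changes the size of the group and removes the ring together, so it cannot say whether either alone matters, and it covers only two groups, both made of carbon alone. As far as these compounds go, a longer chain, or an amine or a carboxylic acid carried at this place, remains open, as does whether any such group would move the number beyond the scatter.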